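Carbamoyl in Place of Cyano: What Compound 4 Might Show

The source may hold more compounds than are shown below. What is called first, only, known or untested is meant among the compounds shown, and "the series" means these compounds.

Compound 2, `N#Cc1cn(COCc2ccccc2)c2ncnc(N)c12`, is measured in a functional assay on KB cells (Homo sapiens) for cytotoxicity (a higher number here means a weaker inhibitor, a lower number a stronger inhibitor), only as a limit, > 100000 nM. Compound 1, `COCCOCn1cc(C#N)c2c(N)ncnc21`, likewise gives only a limit, > 100000 nM. Within the data shown here, the single step between measured compounds that differ in one place, a step that the two limits leave unreadable from compound 1 to compound 2, therefore cannot be read, because both of its values sit at the limit of > 100000 nM in this assay, at which 2 of the 3 values shown sit. Compound 3, `CC(C)(C)c1ccc(Cn2cc(C(N)=O)c3c(N)ncnc32)cc1`, which carries a carbamoyl group and a different substituent on the ring nitrogen, gives 900 nM in this assay. The change that leads to compound 4, `NC(=O)c1cn(COCc2ccccc2)c2ncnc(N)c12`, is carbamoyl in place of cyano on an aromatic carbon. Among the measured compounds shown here, no measured step follows this change alone, and compound 2 and compound 3 differ in two places, so the size of the step cannot be taken from a measured step. For the measured compounds named here, what the numbers show is that the one carbamoyl compound has a measured value, while both cyano compounds stop at the limit. Compound 4 is therefore expected to be the stronger inhibitor, and its estimated step is an at least 12-fold lower number from compound 2 to compound 4 (1.09 log units; beyond the scatter). The estimate for compound 4 is 8000 nM, within a range from 1000 nM to 100000 nM, with a real chance that only a limit is reported again.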

Compound 4, half-maximal inhibitory concentration: > 100000 nM
Compound 4 ended at the assay's limit; the forecaster's own chance of this, stated with the estimate: 35%; middle value at least 12-fold (1.09 log units) away from the limit.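

No step from compound 2 to compound 4 can be read, because both compounds stop at the same limit: the limit of > 100000 nM in this assay, at which 3 of the 4 values shown sit.

The compounds shown leave open whether carbamoyl in place of cyano on an aromatic carbon changes the value in this assay at all.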